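Replacing 3-methoxyphenyl with naphthalen-1-yl in compound 3

A few compounds are considered here, and "the series" means these few. Any claim that something is new, unique, unknown or untested is made for them only; others in the source may bear on it.

In a functional assay on PC-3 cells (Homo sapiens) for inhibition, read by sulforhodamine B assay, with a stated time of 48 h, tested at 50 uM (a lower number here means less inhibition of growth, a higher number more inhibition of growth at the concentration tested), compound 3 (`COc1cccc(/C=C/C(=O)/C=C/c2ccc(OCc3cn(CCCCOc4cc(=O)oc5ccccc45)nn3)c(OC)c2)c1`) is reported as "not active" (no number reported) and has no single number, so it cannot be placed on a numerical scale. Compound 2 (`COc1ccc(/C=C/C(=O)/C=C/c2ccc(OCc3cn(CCCCOc4cc(=O)oc5ccccc45)nn3)c(OC)c2)cc1OC`) is the one further entry of this kind and is reported as "not active" (no number reported) in the same test.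

The step to compound 4 (`COc1cc(/C=C/C(=O)/C=C/c2cccc3ccccc23)ccc1OCc1cn(CCCCOc2cc(=O)oc3ccccc23)nn1`) puts naphthalen-1-yl in place of 3-methoxyphenyl on a double-bonded chain carbon bound to a double-bonded chain carbon and leaves the rest of the structure unchanged.

Without a number for compound 3, the step in this assay can be judged only roughly. A small move toward more inhibition of growth is expected, although a second result without a number remains possible. The basis is compound 1 (`COc1cc(/C=C/C(=O)/C=C/c2cccc3ccccc23)ccc1OCc1cn(CCOc2cc(=O)oc3ccccc23)nn1`), which also carries naphthalen-1-yl and gives 20% in this test. For compound 4 the expected growth inhibition is 15% with an estimated range from 0% to 35% at the tested concentration.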

Compound 4, percent growth inhibition at one concentration: "not active" (no number reported)
Nothing numeric was reported for compound 4, so the estimate cannot be set against anything.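

Compound 3 and compound 4 are both reported as "not active", without a number, in this assay, so no step can be read between them. The compounds shown leave open whether naphthalen-1-yl in place of 3-methoxyphenyl shifts growth inhibition at all. No evidence bears on this result.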